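Fluoro to methyl on the sulfonyl aryl of compound 2

The compounds below may be only part of what the source reports. "The series", "measured", "known", "first", "only" and "open" are said of these compounds alone.

Compound 1 `O=S(=O)(Nc1ccc(CNc2nc(NC3CC3)nc3ccccc23)cc1)c1ccc(F)cc1`: 4100 nM
Compound 2 `CNc1nc(NCc2ccc(NS(=O)(=O)c3ccc(F)cc3)cc2)c2ccccc2n1`: 4800 nM
Compound 3 `CN(C)c1nc(NCc2ccc(C(=O)Nc3ccc(F)cc3)cc2)c2ccccc2n1`: 2600 nM
Compound 4 `CNc1nc(NCc2ccc(NS(=O)(=O)c3ccc(C)cc3)cc2)c2ccccc2n1`: not yet measured

In a functional assay on SW480 cells (Homo sapiens) for inhibition, read by luminescence and resazurin assay, with a stated time of 3 days (on this read-out higher numbers stand for weaker inhibition and lower numbers for stronger inhibition), compound 2 gives 4800 nM, within the scatter of both compound 1 and compound 3. Compound 4 replaces 4-fluorophenyl with 4-methylphenyl on the sulfonyl group: methyl in place of fluoro on an aromatic carbon. Among the measured compounds shown here, no measured step covers this change. The only one available, a 1.2-fold higher number from compound 1 to compound 2 (0.07 log units; within the scatter), is methyl in place of cyclopropyl on a nitrogen, at a different place, and it stays within the scatter. The three values give little guidance, so no shift beyond the scatter is expected, and the estimate stays close to compound 2. The expected change is a 1.1-fold lower number from compound 2 to compound 4 (0.03 log units; within the scatter). Compound 4 is estimated at 4500 nM, with an expected range of 2000 nM to 10000 nM.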

Compound 4, half-maximal inhibitory concentration: 4900 nM
Estimate against measurement, compound 4: 1.1-fold (0.04 log units) below; measured number inside the range.
By their numbers in this assay, from the lowest: compounds 3, 1, 2 and 4 (each within the scatter of the next).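

In this assay the sulfonyl aryl gives its first measured step, with a 1.0-fold higher number from compound 2 to compound 4 (0.01 log units; within the scatter) for methyl in place of fluoro on an aromatic carbon para to a large group. At this place, 4-fluorophenyl and 4-methylphenyl therefore read alike, a point the earlier step at the other nitrogen could not address. Nothing available accounts for this result. Open, from the compounds shown here alone, is whether an amine, a carboxylic acid or a longer chain on this carbon would also stay within the scatter. Also open, going by these compounds, is whether the same exchange would read alike on the cyclopropyl analogue, compound 1.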